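Butyl to isobutyl on the imidazole-free notes

The compounds below may be only part of what the source reports. "The series", "measured", "known", "first", "only" and "open" are said of these compounds alone.

Correction to the title above; the notes begin here.

Butyl to isobutyl: working notes on the series

Compound 1 (`COc1cc(-c2nccn2C(C)C)cc(OC)c1OC`) gives > 100000 nM as a limit of the assay
Compound 2 (`CCCCn1ccnc1-c1cc(OC)c(OC)c(OC)c1`) gives 44100 nM as a measured number

Among the compounds with values here, in a functional assay on MDA-MB-468 cells (Homo sapiens) for antiproliferative activity, read by MTT assay, with a stated time of 72 h (on this read-out lower numbers stand for stronger inhibition and higher numbers for weaker inhibition), compound 2 holds the only actual number so far (44100 nM) and serves as the reference point. Compound 1 gives no number, only a limit (the limit of > 100000 nM in this assay, at which 1 of the 2 values shown sits).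

Compound 3 (`COc1cc(-c2nccn2CC(C)C)cc(OC)c1OC`) has the same atoms as compound 2, joined differently (isopropyl in place of propyl on a saturated chain carbon bound to an aromatic nitrogen), and the same difference reads as butyl to isobutyl. Within the data shown here, one measured step bears on this change, with butyl in place of isopropyl on an aromatic nitrogen (an at least 2.2-fold lower number from compound 1 to compound 2 (0.35 log units; beyond the scatter)). Isopropyl stands on the aromatic nitrogen itself in compound 1, whereas in compound 3 it stands on a saturated chain carbon bound to an aromatic nitrogen, so the comparison is only partial. Given that step (an at least 2.2-fold lower number from compound 1 to compound 2 (0.35 log units; beyond the scatter)), a modest move towards a higher number, meaning weaker inhibition, is expected in this assay for compound 3, and it may not clear the scatter. The estimated step runs as follows (a 1.6-fold higher number from compound 2 to compound 3 (0.20 log units; within the scatter)). Compound 3 is expected at 70000 nM with an estimated range from 30000 nM to 100000 nM in this read-out.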

Compound 3, half-maximal inhibitory concentration: > 100000 nM
Compound 3 ended at the assay's limit; the forecaster's own chance of this, stated with the estimate: 30%; at least 1.4-fold (0.15 log units) between middle value and limit.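

In this assay, within the data shown here, the branch in isobutyl costs activity against the straight butyl chain, with an at least 2.2-fold higher number from compound 2 to compound 3 (0.35 log units; beyond the scatter), so compound 2 remains the only one of the three compounds with a measured number. The earlier pair changed isopropyl to butyl on the aromatic nitrogen, which left chain length and branching tied together; here the atoms stay the same and only the way they are joined differs, so this step isolates the branching at this position. The step from compound 1 to compound 3 cannot be read, and most of the series gives no number to compare: the limit of > 100000 nM in this assay, at which 2 of the 3 values shown sit.

From the compounds shown here alone, compound 3 rests at a limit, so the full size of its step from compound 2 stays open. Also open, going by these compounds, is whether a longer chain such as pentyl, a chain ending in an amine or a carboxylic acid, or another branched chain such as isopentyl on the aromatic nitrogen would give a lower number than compound 2 or join compound 3 at the limit.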